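Shifting one chlorine in compound 3

The source may report more compounds than this note shows. Statements on the series, on what has been measured and on what is new or still open speak of the compounds shown alone.

In a functional assay on A549 cells (Homo sapiens) for antiproliferative activity, read by MTT assay, with a stated time of 48 h (a higher number here means a weaker inhibitor, a lower number a stronger inhibitor), compound 3 `Oc1ccc2ccccc2c1C(Nc1nc2ccc(Cl)cc2s1)c1cn(-c2ccccc2)nc1-c1ccc(Cl)cc1` gives 54100 nM. Compound 1 `Cc1ccc2nc(NC(c3cn(-c4ccccc4)nc3-c3cccc(Cl)c3)c3c(O)ccc4ccccc34)sc2c1` gives 45400 nM, which lies within the scatter of the number for compound 3. Compound 2 `Oc1ccc2ccccc2c1C(Nc1nc2ccccc2s1)c1cn(-c2ccccc2)nc1-c1cccc(Cl)c1` gives 20400 nM, the lowest number of the three.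

Compound 4 `Oc1ccc2ccccc2c1C(Nc1nc2ccc(Cl)cc2s1)c1cn(-c2ccccc2)nc1-c1cccc(Cl)c1` has not yet been measured. It differs from compound 3 in one place, on an aromatic carbon of a five-membered aromatic ring with 2 nitrogen: 3-chlorophenyl in place of 4-chlorophenyl on an aromatic carbon. The same atoms are present, only joined differently.

Going by the values given here, the one measured step is a 2.2-fold lower number from compound 1 to compound 2 (0.35 log units; beyond the scatter), a modest move with hydrogen in place of methyl on an aromatic carbon. It is a different change, so it shows only how far a single small edit has moved the number in this series. Among the compounds with values here, no measured pair exchanges 4-chlorophenyl for 3-chlorophenyl directly. Compound 1 and compound 2 do carry the 3-chlorophenyl group, and they are the closest guide available, though they also differ from compound 4 elsewhere.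

The expected change is small and within the scatter, a 1.4-fold lower number from compound 3 to compound 4 (0.15 log units; within the scatter). For compound 4 the estimated value in this assay is 38000 nM, with an expected range from 16000 nM to 80000 nM.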

Compound 4, half-maximal inhibitory concentration: 33300 nM
Beside the measured number, compound 4's estimate is 1.1-fold (0.06 log units) above it; low and high end bracket the measured number.
By their numbers in this assay, from the lowest: compounds 2, 4, 1 and 3 (each within the scatter of the next, the first and the last beyond it).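

In this assay, going by these compounds alone, the first direct reading of 3-chlorophenyl in place of 4-chlorophenyl on an aromatic carbon of the five-membered ring is a 1.6-fold lower number from compound 3 to compound 4 (0.21 log units; within the scatter) and so moving the chlorine around that phenyl ring, with the same atoms present, does not clearly separate the two compounds. At the other site of change, chloro in place of hydrogen gives a 1.6-fold higher number from compound 2 to compound 4 (0.21 log units; within the scatter) while chloro in place of methyl gives a 1.4-fold lower number from compound 1 to compound 4 (0.13 log units; within the scatter) and so compound 4 cannot be told apart from either neighbour, although the earlier step between hydrogen and methyl lay beyond the scatter. No measurement on hand explains these small differences or the larger earlier step.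

The compounds shown carry only chlorine on this phenyl ring, so it remains open whether a different group there, such as an amine or a carboxylic acid, would shift the number beyond the scatter. All of these readings also come from a single cell line, which leaves open whether the same small differences hold in other cells.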